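This account rests on a few compounds, and the source may have more. Where it says the series, first, only, none or still open, it means among the compounds named here.

Of the compounds shown here, three have been measured in a functional assay on DU-145 cells (Homo sapiens) for cytotoxicity, read by sulforhodamine B assay, with a stated time of 48 h; on this read-out higher numbers stand for weaker inhibition and lower numbers for stronger inhibition. Compound 1 `COc1ccc2c(c1)c(/C=N/O)cn2Cc1cn([C@@H]2O[C@H](COC(C)=O)[C@@H](OC(C)=O)[C@H](OC(C)=O)[C@H]2OC(C)=O)nn1` gives 88400 nM. Compound 2 `CC(=O)OC[C@H]1O[C@@H](n2cc(CN3C(=O)/C(=C\c4ccc(N(C)C)cc4)c4ccccc43)nn2)[C@H](OC(C)=O)[C@@H](OC(C)=O)[C@@H]1OC(C)=O` gives 10100 nM. Compound 3 `CC(=O)OC[C@H]1O[C@@H](n2cc(CN3C(=O)/C(=C/c4ccc(N(C)C)cc4)c4ccccc43)nn2)[C@H](OC(C)=O)[C@@H](OC(C)=O)[C@@H]1OC(C)=O` gives 11200 nM, which places compound 3 second highest of the three numbers, close to compound 2 and far from compound 1. For the measured compounds named here, the only step between two measured compounds that differ in one place is a 1.1-fold higher number from compound 2 to compound 3 (0.04 log units; within the scatter), and it rests on (the fact that compounds 2 and 3 differ only in the configuration as drawn), so the drawn geometry of the double bond made no difference that rises above the scatter.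

Compound 4 `CC(=O)OC[C@H]1O[C@@H](n2cc(CN3C(=O)/C(=C/c4ccco4)c4ccccc43)nn2)[C@H](OC(C)=O)[C@@H](OC(C)=O)[C@@H]1OC(C)=O` is not yet measured. It differs from compound 3 by furan-2-yl in place of 4-(dimethylamino)phenyl on a double-bonded chain carbon bound to a double-bonded ring carbon. Going by the values given here, no measured step involves an exchange of this group, so the step from compound 2 to compound 3 does not bear on it directly, and nothing in the data points to a direction. A modest movement in either direction, or none beyond the scatter, is the expectation, written as a 1.3-fold higher number from compound 3 to compound 4 (0.13 log units; within the scatter). Compound 4 is therefore estimated at 15000 nM, with a range from 5000 nM to 50000 nM.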

Compound 4, half-maximal inhibitory concentration: 10000 nM
For compound 4 the middle estimate is 1.5-fold (0.18 log units) above the measured one; the range from low to high includes it.
By their numbers in this assay, from the lowest: compounds 4, 2 and 3 (each within the scatter of the next); then compound 1.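

The earlier compounds shown here showed only that the drawn geometry of this double bond made no clear difference, whereas here the group carried on it is exchanged. With furan-2-yl in place of 4-(dimethylamino)phenyl on a double-bonded chain carbon bound to a double-bonded ring carbon, this assay shows a 1.1-fold lower number from compound 3 to compound 4 (0.05 log units; within the scatter), so in this pair a smaller five-membered aromatic ring of 5 heavy atoms does as well as a six-membered one in a group of 9 heavy atoms. Nothing at hand accounts for this result.

Only these two aromatic groups are shown at this position, so it remains open whether a non-aromatic group, such as an amine, a carboxylic acid or a longer alkyl chain, would shift the number beyond the scatter. Also open, as far as these compounds go, is whether the furan-2-yl compound with the double bond drawn the other way would match compound 4.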